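From compound 3 to compound 4: methyl replaced by bromo

The compounds below may be only part of what the source reports. "The series", "measured", "known", "first", "only" and "open" are said of these compounds alone.

In a functional assay on U-87MG ATCC cells for inhibition, with U-87 MG (Homo sapiens) as the target, read by sulforhodamine B assay, with a stated time of 72 h (on this read-out higher numbers stand for an effect only at larger amounts of compound and lower numbers for an effect already at smaller amounts), compound 3 `Cc1cccc(C(=O)/C=C/c2ccc([N+](=O)[O-])o2)c1` gives 3300 nM and shares the low end of the three numbers with compound 1 `CCCCc1ccc(C(=O)/C=C/c2ccc([N+](=O)[O-])o2)cc1` at 5800 nM as the two values lie within the scatter of each other. Compound 2 `O=C(/C=C/c1ccc([N+](=O)[O-])o1)c1ccc(N2CCCC2)cc1` at 35400 nM stands apart from both, beyond the scatter.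

The next structure is compound 4 `O=C(/C=C/c1ccc([N+](=O)[O-])o1)c1cccc(Br)c1` and the difference from compound 3 is bromo in place of methyl on an aromatic carbon. The shared core stays unchanged.

Within the data shown here, only one measured step offers any guide: a 6.1-fold higher number from compound 1 to compound 2 (0.79 log units; beyond the scatter) for pyrrolidin-1-yl in place of butyl on an aromatic carbon. That step is modest but beyond the scatter. Among the measured compounds shown here, it involves a different pair of groups, so it bears on the present change only loosely, and no measured compound yet carries bromo. Its size is therefore taken as an outer bound, not as a forecast.

In this assay no step beyond the scatter is expected, with the expected change being a 1.2-fold lower number from compound 3 to compound 4 (0.07 log units; within the scatter) and its direction left open by the data. For compound 4 the estimated value is 2800 nM with an expected range from 1200 nM to 7000 nM.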

Compound 4, half-maximal effective concentration: 6800 nM
Compound 4: the middle estimate sits 2.4-fold (0.39 log units) below what was measured, and the stated range covers the measured number.
By their numbers in this assay, from the lowest: compounds 3, 1 and 4 (each within the scatter of the next, the first and the last beyond it); then compound 2.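

In this assay, bromo in place of methyl on an aromatic carbon, meta to a large group, gives a 2.1-fold higher number from compound 3 to compound 4 (0.31 log units; beyond the scatter) and so provides the first step read at this position. Among these compounds, the position therefore responds to a swap in which each group counts one heavy atom and neither brings a hydrogen-bond donor or acceptor, although the step remains modest; the only earlier step, a 6.1-fold higher number from compound 1 to compound 2 (0.79 log units; beyond the scatter), involved butyl and pyrrolidin-1-yl and could say nothing about methyl and bromo at this place. No measurement available here bears on why the number moves with this change.

The compounds shown leave open whether this position tolerates groups of another kind, such as an amine, a carboxylic acid or a longer chain, and whether any group there would bring the number below that of compound 3 at 3300 nM by more than the scatter. Among the compounds shown here, it also remains open whether bromo would give a step of similar size and direction at another place on the same ring, since the series so far offers no pair that tests this.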